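Methylcarbamoyl for methylsulfanyl: working notes on compound 3

The compounds below may be only part of what the source reports. "The series", "measured", "known", "first", "only" and "open" are said of these compounds alone.

In a functional assay on HeLa cells (Homo sapiens) for antiproliferative activity, read by CCK-8 assay, with a stated time of 72 h (a higher number here means a weaker inhibitor, a lower number a stronger inhibitor), compound 1 (`COc1ccc(-c2cncnc2-c2cc(OC)c(OC)c(OC)c2)cc1O`) gives 280 nM and compound 2 (`COc1cc(-c2ncncc2-c2ccc(SC)cc2)cc(OC)c1OC`) gives 220 nM on the same read-out. For the measured compounds named here, these two values sit within the scatter of each other, so compound 2 stands level with its only measured neighbour. Going by the values given here, the one measured step is a 1.3-fold lower number from compound 1 to compound 2 (0.10 log units; within the scatter) and it puts 4-(methylsulfanyl)phenyl in place of 3-hydroxy-4-methoxyphenyl on an aromatic carbon.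

Compound 3 (`CNC(=O)c1ccc(-c2cncnc2-c2cc(OC)c(OC)c(OC)c2)cc1`) has methylcarbamoyl in place of methylsulfanyl on an aromatic carbon, para to a large group (methylcarbamoyl in place of methylsulfanyl on an aromatic carbon). Among the compounds with values here, only that one step bears on this change, and only loosely. It shows one exchange on the same ring passing without a move beyond the scatter, but neither compound 1 nor compound 2 carries methylcarbamoyl. The data hold no direct measure of this group, so any direction is a judgement. A move toward weaker inhibition is the expected outcome, with a 6.8-fold higher number from compound 2 to compound 3 (0.83 log units; beyond the scatter) as the estimated step in this assay here. The estimated value for compound 3 is 1500 nM within an expected range of 300 nM to 10000 nM and that range is deliberately wide.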

Compound 3, half-maximal inhibitory concentration: 1470 nM
Estimate against measurement, compound 3: 1.0-fold (0.01 log units) above; the measured number falls inside the stated range.
By their numbers in this assay, from the lowest: compounds 2 and 1 (each within the scatter of the next); then compound 3.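

Methylcarbamoyl in place of methylsulfanyl gives the first step in this assay that lies beyond the scatter, a 6.7-fold higher number from compound 2 to compound 3 (0.82 log units; beyond the scatter), whereas the earlier step on this ring stayed within it. The position on the aromatic carbon, para to a large group, is therefore not indifferent to the group it carries, and of the groups shown here methylcarbamoyl goes with the higher number. The exchange replaces 2 heavy atoms and 0 hydrogen-bond donors with 4 heavy atoms, 1 hydrogen-bond donor and 1 double bond outside aromatic rings, and no measurement here gives a reason for the step or assigns it to any one of these differences.

The compounds shown leave open whether the higher number follows the amide hydrogen, the carbonyl or the extra size, a question that an acetyl group or a dimethylcarbamoyl group at the same position would help to separate. They also leave open how a carboxylic acid, an amine or a longer chain on the sulfur would read in this assay on the shared core.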